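Hydroxy to methoxy on an aryl hydrazone series

A few compounds are considered here, and "the series" means these few. Any claim that something is new, unique, unknown or untested is made for them only; others in the source may bear on it.

Compound 1 `Cn1nnnc1SCC(=O)N/N=C/c1ccccc1O`, compound 2 `Cn1nnnc1SCC(=O)N/N=C/c1cccc(O)c1` and compound 3 `COc1ccccc1/C=N/NC(=O)CSc1nnnn1C` have been measured in an ADME assay on NIH3T3 cells (Mus musculus) for cytotoxicity, read by XTT assay, with a stated time of 24 h; on this read-out lower numbers stand for stronger inhibition and higher numbers for weaker inhibition; compound 4 `COc1cccc(/C=N/NC(=O)CSc2nnnn2C)c1` has not. Compound 1 reaches only a limit of this assay and no number, > 10000000 nM, which is the limit of > 10000000 nM in this assay, at which 1 of the 3 values shown sits. Compound 2 gives 3160000 nM in this assay. Compound 3 gives 3160000 nM in this assay, level with compound 2 at the digits shown and within the scatter, so no order between these two is drawn.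

Going by the values given here, the single change measured between two compounds is methyl in place of hydrogen on an oxygen on an aromatic ring. It gives an at least 3.1-fold lower number from compound 1 to compound 3 (0.50 log units; beyond the scatter), the true size being open at the upper end since compound 1 sits at a limit. Compound 2 and compound 1 have the same atoms joined differently; the difference between the two cores is not broken down here. From compound 2 to compound 4 the change is methyl in place of hydrogen on an oxygen on an aromatic ring, the same change as from compound 1 to compound 3, with the place described in the same words.

In this assay the expected step is a 1.3-fold lower number from compound 2 to compound 4 (0.10 log units; within the scatter). This rests on compound 3 giving 3160000 nM and compound 2 giving 3160000 nM, the same number on both sides, and on the step of an at least 3.1-fold lower number from compound 1 to compound 3 (0.50 log units; beyond the scatter) being only a lower bound. Compound 4 is therefore estimated at 2500000 nM, with the expected range 800000 nM to 8000000 nM.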

Compound 4, half-maximal inhibitory concentration: 600000 nM
Compound 4: the middle estimate sits 4.2-fold (0.62 log units) above what was measured, outside the stated range (below it).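

Hydroxy to methoxy moves the number the same way on both cores in this assay: it gives a 5.3-fold lower number from compound 2 to compound 4 (0.72 log units; beyond the scatter), beside the earlier at least 3.1-fold lower number from compound 1 to compound 3 (0.50 log units; beyond the scatter), so the direction of the step carries over from the core of compound 1 to the core of compound 2 in these two pairs, and both steps lie beyond the scatter. Whether the size of the step also carries over is not shown, and the two steps cannot be ranked against each other: the same change on two cores in this assay, an at least 3.1-fold lower number (0.50 log units; beyond the scatter) from compound 1 to compound 3 and a 5.3-fold lower number (0.72 log units; beyond the scatter) from compound 2 to compound 4; the limit leaves it open whether they differ Two pairs make no rule for other cores in the series, and the reading of the first pair remains tied to one open-ended value: the limit of > 10000000 nM in this assay, at which 1 of the 4 values shown sits.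

The compounds shown leave open whether a longer chain on that oxygen, such as ethyl or propyl in place of methyl, would give a step of the same direction on both cores. They also leave open what an amine or a carboxylic acid in place of the hydroxy would do in this assay, so the step is known only for methyl in place of hydrogen.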